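A few compounds are considered here, and "the series" means these few. Any claim that something is new, unique, unknown or untested is made for them only; others in the source may bear on it.

Compound 1 `COc1ccc(Oc2ccc3nncn3n2)cc1`: in a functional assay on the whole organism with Mus musculus as the target (a lower number here means that less compound is needed, a higher number that more compound is needed for the effect), compound 1 gives > 100 mg/kg.
Compound 2 `Clc1cccc(Oc2ccc3nncn3n2)c1`: in this assay compound 2 gives 39.4 mg/kg.

Both compounds share the same core and differ only in the group carried on the six-membered aromatic ring of carbon only. For compound 1 the result is a limit of the assay and not a number: compound 1 sits at the limit of > 100 mg/kg in this assay, at which 1 of the 2 values shown sits. Compound 2, which carries chloro, gives a number inside the measured range, 39.4 mg/kg.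

Compound 3 `Brc1ccc(Oc2ccc3nncn3n2)cc1` has not yet been measured. It differs from compound 1 by bromo in place of methoxy on an aromatic carbon, in words bromo in place of methoxy on an aromatic carbon. Going by the values given here, no measured pair of compounds shows this exact change, so the size of the step cannot be read from data. Among the compounds with values here, the only guide is that compound 2, carrying a halogen, reaches a number where compound 1 reaches only a limit. The step from compound 1 to compound 3 is therefore expected to go toward a lower dose, as an at least 2.0-fold lower number from compound 1 to compound 3 (0.30 log units; that floor lies within the scatter). Compound 3 is estimated at 50 mg/kg, within a range from 15 mg/kg to 160 mg/kg.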

Compound 3, dose for half-maximal effect: 49.1 mg/kg
Beside the measured number, compound 3's estimate is 1.0-fold (0.01 log units) above it, within the range that was stated.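

Placing bromo in place of methoxy on an aromatic carbon, para to a large group, turns this position from one that gave no number in this assay into one that gives a number, and it does so with a halogen at the same place as the methoxy of compound 1. Compound 1 stays a limit of the assay and not a number, and it is the only compound shown that does: the limit of > 100 mg/kg in this assay, at which 1 of the 3 values shown sits. The change can therefore be read only as an at least 2.0-fold lower number from compound 1 to compound 3 (0.30 log units; that floor lies within the scatter), which fixes the direction of the reading but gives a floor and not a true size, and that floor alone does not clear the usual scatter.

As far as these compounds go, what remains open is whether the gain comes from bromo arriving or simply from methoxy leaving, and whether an amine, a carboxylic acid or a longer chain at this same place would also give a number in this assay. From the compounds shown here alone, how large the step really is also stays unknown, as one end of it is a limit.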